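Swapping trifluoromethyl for chloro on a fused bicyclic antagonist

The compounds below may be only part of what the source reports. "The series", "measured", "known", "first", "only" and "open" are said of these compounds alone.

Measured compounds:
Compound 1, `CC(C(=O)O)c1nn(Cc2cn3cc(OCC4CC4)c(C(F)(F)F)cc3n2)c2ccccc2c1=O`, gives 5 nM.
Compound 2, `O=C(O)Cn1nc(Cc2cn3cc(OCC4CC4)c(Cl)cc3n2)c2ccccc2c1=O`, gives 7.6 nM.
Compound 3, `O=C(O)Cn1nc(Cn2cc3cc(OCC4CC4)c(Cl)cc3n2)c2ccccc2c1=O`, gives 8.1 nM.

All three were tested in a functional assay on HFL1 cells for antagonist activity at sphingosine 1-phosphate receptor 2 (Homo sapiens), read by ELISA, with a stated time of 24 h; on this read-out higher numbers stand for weaker inhibition and lower numbers for stronger inhibition. Compound 1 has the lowest of the three numbers, but its gap to compound 2 and its gap to compound 3 are both within the scatter, so no ordering among the three can be claimed; they read as equally strong inhibitors.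

Compound 4, `CC(C(=O)O)c1nn(Cc2cn3cc(OCC4CC4)c(Cl)cc3n2)c2ccccc2c1=O`, has not been measured. It differs from compound 1 in one place: chloro in place of trifluoromethyl on an aromatic carbon. Among the compounds with values here, compound 2 and compound 3 already carry a chloro at this position and give numbers close to that of compound 1, though each also differs from compound 1 elsewhere, so no single pair isolates the swap.

Given how little the three measured values spread, the step of a 1.2-fold higher number from compound 1 to compound 4 (0.08 log units; within the scatter) is expected to be small, with no clear direction beyond the scatter. Compound 4 is therefore estimated to give 6 nM in this assay, within a range from 2.5 nM to 15 nM.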

Compound 4, half-maximal inhibitory concentration: 1.3 nM
The estimate for compound 4 lay 4.6-fold (0.66 log units) above the measured number; measured number below the stated range.
By their numbers in this assay, from the lowest: compound 4; then compounds 1, 2 and 3 (each within the scatter of the next).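

In this assay, the step from trifluoromethyl to chloro gives a 3.8-fold lower number from compound 1 to compound 4 (0.59 log units; beyond the scatter), a change beyond the scatter and towards stronger inhibition. Within the data shown here, this pair isolates the group on the aromatic carbon ortho to the cyclopropylmethoxy group, which the earlier compounds could not do because each differed from compound 1 elsewhere as well. It shows that this position is not indifferent to the swap: on the core of compound 1, chloro, with 1 heavy atom, outperforms trifluoromethyl, with 4 heavy atoms, even though the earlier close spread of values hinted at little effect, and no measurement shown here accounts for the difference.

Going by these compounds, this is a single pair, so it remains open whether the same swap would have a similar effect on compound 2 or compound 3, neither of which has a trifluoromethyl partner here. On these data alone, it is also open how other groups on this aromatic carbon, such as bromo, nitrile or methoxy, would compare with chloro.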